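A few compounds are considered here, and "the series" means these few. Any claim that something is new, unique, unknown or untested is made for them only; others in the source may bear on it.

Measured in an ADME assay on MT4 cells (Homo sapiens) for cytotoxicity, read by MTT assay, with a stated time of 96 h; a higher number here means that more compound is tolerated, a lower number that less compound is tolerated:
compound 1, `COc1ccc(-c2nc3cc(Cl)c(Cl)cc3[nH]2)c(N)c1`: 3000 nM
compound 2, `CCN(CC)CC(=O)Nc1ccc(-c2nc3cc(C(F)(F)F)ccc3n2C)cc1`: 9000 nM
compound 3, `O=C(CN1CCCC1)Nc1ccc(-c2nc3cc(C(F)(F)F)ccc3[nH]2)cc1`: 18000 nM

Compound 2 gives the second-highest of the three numbers. Its nearest neighbour is compound 3, whose number lies within the scatter of that of compound 2, so the two cannot be told apart. Among the compounds with values here, compound 1 gives a number beyond the scatter and lower than that of compound 2; the two differ in several places at once, and no single step connects them. Within the data shown here, no pair of measured compounds differs in one place only, so the effect of any single change has not yet been measured.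

Compound 4, `CC(=O)Nc1ccc(-c2nc3cc(C(F)(F)F)ccc3n2C)cc1`, differs from compound 2 in one place: hydrogen in place of diethylamino on a saturated chain carbon bound to a carbonyl carbon. The rest of the molecule, including the acetamido attachment to the shared core, is unchanged. Nothing in the measured compounds shows what this change does on its own, so the expectation rests on compound 2 at 9000 nM and on the two closely agreeing numbers of compound 2 and compound 3. The expected step is a 1.3-fold higher number from compound 2 to compound 4 (0.12 log units; within the scatter), no larger than the scatter, leaning if anything toward a higher number. Compound 4 is expected near 12000 nM, within 5000 nM to 30000 nM in this assay.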

Compound 4, half-maximal cytotoxic concentration: 15000 nM
Beside the measured number, compound 4's estimate is 1.3-fold (0.10 log units) below it, within the range that was stated.
By their numbers in this assay, from the lowest: compound 1; then compounds 2, 4 and 3 (each within the scatter of the next).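

Within the data shown here, the first single-place step, a 1.7-fold higher number from compound 2 to compound 4 (0.22 log units; within the scatter) in this assay, is hydrogen in place of diethylamino on a saturated chain carbon bound to a carbonyl carbon. The numbers of the two compounds cannot be told apart, so at this place the whole diethylamino group, with its 5 heavy atoms and its hydrogen-bond acceptor, can go without a difference beyond the scatter, and the acetamido compound stands in the same range as the larger (((diethylamino)methyl)carbonyl)amino compound. No measurement shown here gives a reason for this result.

Open, from the compounds shown here alone, is what a carboxylic acid or a longer alkyl chain on this saturated chain carbon would give in this assay. Also open, going by these compounds, is whether hydrogen in place of the amine gives a comparable step on the core of compound 3.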